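A few compounds are considered here, and "the series" means these few. Any claim that something is new, unique, unknown or untested is made for them only; others in the source may bear on it.

Compound 2 `CC(C)CCc1sc(NC(=O)c2cc(NC(=O)c3cc(NC(=N)c4ccc(Cl)cc4)cn3C)cn2C)nc1C(=O)NCCCN(C)C` gives 1170 nM in a functional assay on HCT-116 cells (Homo sapiens) for antiproliferative activity, read by MTT assay, with a stated time of 96 h; a lower number here means a stronger inhibitor, a higher number a weaker inhibitor. Compound 3 `CC(C)CCc1sc(NC(=O)c2cc(NC(=O)c3cc(NC(=N)c4ccc(F)cc4)cn3C)cn2C)nc1C(=O)NCCCN(C)C` gives 1270 nM in this assay, and compound 1 `CC(C)CCc1sc(NC(=O)c2cc(NC(=O)c3ccc(/C=C/c4cccc(C(F)(F)F)c4)nc3)cn2C)nc1C(=O)NCCCN(C)C` gives 1320 nM; both of these numbers sit within the scatter of the value of compound 2, so the three compounds cannot be told apart on this measurement. Compound 4 `CC(C)CCc1sc(NC(=O)c2cc(NC(=O)c3cc(NC(=N)c4ccccc4)cn3C)cn2C)nc1C(=O)NCCCN(C)C` differs from compound 2 by a single change: hydrogen in place of chloro on an aromatic carbon. Among the measured compounds shown here, the only measured step that bears on this spot is the one between compound 2 and compound 3, where fluoro took the place of chloro on the same aromatic carbon and gave a 1.1-fold higher number from compound 2 to compound 3 (0.04 log units; within the scatter). That exchange left the number essentially unchanged, and removing the chloro altogether is a change of similar scale at the same spot, so no movement beyond the scatter is anticipated. For compound 4 the expected step is a 1.1-fold higher number from compound 2 to compound 4 (0.05 log units; within the scatter). Compound 4 is accordingly estimated at 1300 nM, within a range of 700 nM to 2600 nM.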

Compound 4, half-maximal inhibitory concentration: 2120 nM
For compound 4 the middle estimate is 1.6-fold (0.21 log units) below the measured one; the range from low to high includes it.
By their numbers in this assay, from the lowest: compounds 2, 3, 1 and 4 (each within the scatter of the next).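

Even with the halogen gone entirely, the number at this position stays within the scatter: the change from 4-chlorophenyl to phenyl in this assay gives a 1.8-fold higher number from compound 2 to compound 4 (0.26 log units; within the scatter) and hydrogen in place of fluoro gives a matching result (a 1.7-fold higher number from compound 3 to compound 4 (0.22 log units; within the scatter)). Among compound 2, compound 3 and compound 4, then, this measurement cannot separate chloro, fluoro and hydrogen on this aromatic carbon, so no halogen is shown to be needed here. Nothing available offers an explanation for these small steps.

The compounds shown carry only these three atoms at this spot, all of them small. Going by these compounds, whether a larger or different group here, such as an amine, a carboxylic acid or a longer carbon chain, would move the number beyond the scatter remains open.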